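This account rests on a few compounds, and the source may have more. Where it says the series, first, only, none or still open, it means among the compounds named here.

Compound 2 `Cc1c(Cc2ccccc2C(O)c2ccccc2)c2c(n1CC(=O)O)CCNC2=O` gives the lower of the two numbers in a functional assay on CHO.K1 cells for antagonist activity at prostaglandin D2 receptor 2 (Homo sapiens), read by GTPgammaS binding, with a stated time of 1 h; on this read-out higher numbers stand for weaker inhibition and lower numbers for stronger inhibition; its nearest neighbour, compound 1 `Cc1c(Cc2ccccc2C(=O)c2ccccc2)c2c(n1CC(=O)O)CCNC2=O`, gives 810 nM, while compound 2 gives 32 nM. Compound 3 `Cc1c(Cc2ccccc2-c2cccc3ccccc23)c2c(n1CC(=O)O)CCNC2=O` differs from compound 2 by naphthalen-1-yl in place of hydroxy(phenyl)methyl on an aromatic carbon. Among the compounds with values here, only one measured step bears on this region, a 25-fold lower number from compound 1 to compound 2 (1.40 log units; beyond the scatter), which shows that changes at this aromatic carbon move the number strongly. Since the hydroxy(phenyl)methyl with its hydrogen-bond donor is removed, compound 3 is expected to move back toward compound 1, by a 7.8-fold higher number from compound 2 to compound 3 (0.89 log units; beyond the scatter). Compound 3 is therefore estimated at 250 nM, within 40 nM to 1500 nM.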

Compound 3, half-maximal inhibitory concentration: 480 nM
Estimate against measurement, compound 3: 1.9-fold (0.28 log units) below; low and high end bracket the measured number.
By their numbers in this assay, from the lowest: compound 2; then compounds 3 and 1 (each within the scatter of the next).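

In this assay there is a 15-fold higher number from compound 2 to compound 3 (1.18 log units; beyond the scatter) on exchanging hydroxy(phenyl)methyl for naphthalen-1-yl, so the added aromatic ring does not restore what that group gives at this aromatic carbon. The same group, set against benzoyl, gives a 1.7-fold lower number from compound 1 to compound 3 (0.23 log units; within the scatter) and lies within the scatter, leaving only hydroxy(phenyl)methyl apart among the three groups. No evidence is available to explain this difference. As far as these compounds go, it remains open whether the number of compound 2 follows the hydroxyl alone or the hydroxyl together with its phenyl ring. A hydroxymethyl or a benzyl group on this carbon would separate the two.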